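The source may report more compounds than this note shows. Statements on the series, on what has been measured and on what is new or still open speak of the compounds shown alone.

Of the compounds shown here, three sharing one core have been measured in a functional assay on L1210 cells (Mus musculus) for inhibition, read by cell counting, with a stated time of 2 days; a lower number here means a stronger inhibitor, a higher number a weaker inhibitor. Compound 1 `C=C(Br)C(=O)Nc1cccc(-c2cn3nc(Cc4cccc(OC)c4)sc3n2)c1` gives 2000 nM. Compound 2 `C=C(Br)C(=O)Nc1cccc(-c2cn3nc(Cc4ccccc4)sc3n2)c1` gives 3000 nM. Compound 3 `C=C(Br)C(=O)Nc1cccc(-c2cn3nc(-c4cccc(OC)c4)sc3n2)c1` gives 580 nM, the lowest of the three numbers. The step of a 3.4-fold lower number from compound 1 to compound 3 (0.54 log units; beyond the scatter) and the step of a 5.2-fold lower number from compound 2 to compound 3 (0.71 log units; beyond the scatter) both lie beyond the scatter, so compound 3 stands apart as the strongest inhibitor of the set. The step of a 1.5-fold higher number from compound 1 to compound 2 (0.18 log units; within the scatter) is within the scatter.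

Compound 4 `C=C(Br)C(=O)Nc1cccc(-c2cn3nc(-c4cccs4)sc3n2)c1` is not yet measured. It differs from compound 3 in one place: thiophen-2-yl in place of 3-methoxyphenyl on an aromatic carbon. Two features of this change can be weighed against the measured steps. The gain seen in a 3.4-fold lower number from compound 1 to compound 3 (0.54 log units; beyond the scatter) and in a 5.2-fold lower number from compound 2 to compound 3 (0.71 log units; beyond the scatter) came when a benzyl-type group gave way to an aromatic ring set on the core itself, and compound 4 also carries an aromatic ring set on that carbon, so that gain need not be lost. The loss of the methoxy group, the only other part of the change, has a parallel in a 1.5-fold higher number from compound 1 to compound 2 (0.18 log units; within the scatter), which changed little. Within the data shown here, no measured pair tests the exchange of a six-membered ring for thiophen-2-yl. The expected step is therefore small, a 1.6-fold higher number from compound 3 to compound 4 (0.19 log units; within the scatter), tending if anything toward a slightly higher number. Compound 4 is estimated at 900 nM in this assay, with a likely range from 300 nM to 2700 nM.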

Compound 4, half-maximal inhibitory concentration: 170 nM
The estimate for compound 4 lay 5.3-fold (0.72 log units) above the measured number; the measured number lies below the stated range.
By their numbers in this assay, from the lowest: compound 4; then compound 3; then compounds 1 and 2 (each within the scatter of the next).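

On the aromatic carbon next to the ring nitrogen and the ring sulfur of the shared core, the choice of directly attached ring still matters: thiophen-2-yl in place of 3-methoxyphenyl gives a 3.4-fold lower number from compound 3 to compound 4 (0.53 log units; beyond the scatter), so the earlier gain from setting a ring directly on this carbon was not the whole story. Compared with the benzyl-type groups, thiophen-2-yl gives an 18-fold lower number from compound 2 to compound 4 (1.25 log units; beyond the scatter) and a 12-fold lower number from compound 1 to compound 4 (1.07 log units; beyond the scatter), the two largest steps in the set, which shows that this one position can move the number much further than the first three compounds revealed. Nothing available accounts for the lower number of compound 4.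

The step from compound 3 to compound 4 changes the ring and removes the methoxy group at once, so the compounds shown cannot separate these two parts, though a plain phenyl group at this carbon would help to do so. Also open, from the compounds shown here alone, is how other groups would fare here, such as thiophen-3-yl, furan-2-yl, a thiophen-2-yl ring carrying a methoxy group or chlorine, or an amine.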